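Ester in place of amide on a thiophene-bearing core

This account rests on a few compounds, and the source may have more. Where it says the series, first, only, none or still open, it means among the compounds named here.

Measured compounds:
compound 1, `CC1=C(C(N)=O)C(c2ccoc2)NC(=O)N1`: 2%
compound 2, `CC1=C(C(N)=O)C(c2ccsc2)NC(=O)N1`: 1%
compound 3, `CC1=C(c2ncc(C)o2)C(c2ccsc2)NC(=O)N1`: 2%

In an assay on membranes from HeLa cells for displacement of a labelled ligand from adenosine receptor A3 (Homo sapiens), read by scintillation counting, with a stated time of 180 min, tested at 1 uM (on this read-out lower numbers stand for less inhibition and higher numbers for more inhibition at the one concentration tested (going by the name of the read-out)), compound 1 gives 2%, compound 2 gives 1% and compound 3 gives 2%. Compound 2 stands among its neighbours without any separation: the move a number 1 percentage points lower from compound 1 to compound 2 (within the scatter) and the move a number 1 percentage points higher from compound 2 to compound 3 (within the scatter) both stay inside the usual scatter, so the three compounds cannot be told apart on these numbers.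

Compound 4, `CCC(CC)OC(=O)C1=C(C)NC(=O)NC1c1ccsc1`, differs from compound 2 in one place: (pentan-3-yl)oxy in place of amino on a carbonyl carbon. Neither measured step tries this change. The closest comparison is the step from compound 2 to compound 3, which replaces the whole carbamoyl group and gives a number 1 percentage points higher from compound 2 to compound 3 (within the scatter). Every change seen so far on this core leaves the read-out flat, so no step beyond the scatter is expected for compound 4 in this assay, meaning a number 2 percentage points higher from compound 2 to compound 4 (within the scatter). Compound 4 is therefore estimated at 3%, with a range from -8% to 15%.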

Compound 4, a percentage reported as inhibition, at one concentration (the size of the read-out at that concentration, not a potency): 6%
Estimate against measurement, compound 4: 3 percentage points below; low and high end bracket the measured number.
By their numbers in this assay, from the lowest: compounds 2, 1, 3 and 4 (each within the scatter of the next).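

In this assay, the carbonyl carbon whose other neighbour is a double-bonded ring carbon now carries (pentan-3-yl)oxy in place of amino, and this gives a number 5 percentage points higher from compound 2 to compound 4 (within the scatter). This change goes further than a swap of similar groups: it removes the hydrogen-bond donor of the amino group and brings in 6 heavy atoms in place of 1, yet compound 4 cannot be told apart from compound 2 on this read-out. Nothing in the data shown offers an explanation for this result.

The compounds shown do not tell whether a small methoxy group or a hydroxyl, which would make a carboxylic acid, on this carbonyl carbon would also stay within the scatter of compound 2. They also leave open whether (pentan-3-yl)oxy would give the same reading with furan-3-yl in place of thiophen-3-yl on the saturated ring carbon.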